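This account rests on a few compounds, and the source may have more. Where it says the series, first, only, none or still open, it means among the compounds named here.

Measured so far:
Compound 1, `CC1=NC(c2cn(S(=O)(=O)c3ccc(C)cc3)c3ccccc23)CN1`: 10000 nM
Compound 2, `CC1=NC(c2cn(S(=O)(=O)c3ccc(F)cc3)c3ccc(C)cc23)CN1`: 9400 nM

Both were tested in an assay on isolated protein for inhibition of kallikrein-7 (Homo sapiens), read by fluorescence, with stated times of 10 min and 30 min; on this read-out lower numbers stand for stronger inhibition and higher numbers for weaker inhibition. Compound 2 gives 9400 nM and compound 1 gives 10000 nM; the two numbers lie within the scatter of each other, so compound 2 stands level with compound 1 rather than apart from it.

Compound 3, `CC1=NC(c2cn(S(=O)(=O)c3ccccc3C#N)c3ccc(C)cc23)CN1`, has not yet been measured. It differs from compound 2 in one place: 2-cyanophenyl in place of 4-fluorophenyl on a sulfonyl sulfur. For the measured compounds named here, no measured pair shows such a change, so the size of the step cannot be read from the data. The expected step from compound 2 to compound 3, a 1.2-fold lower number from compound 2 to compound 3 (0.07 log units; within the scatter), is a small one, not beyond the scatter. Compound 3 is estimated at 8000 nM, with a range from 3000 nM to 25000 nM.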

Compound 3, half-maximal inhibitory concentration: 6700 nM
Beside the measured number, compound 3's estimate is 1.2-fold (0.08 log units) above it; the measured number falls inside the stated range.
By their numbers in this assay, from the lowest: compounds 3, 2 and 1 (each within the scatter of the next).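

In this assay, for the compounds shown here, the only direct comparison at this position, 2-cyanophenyl in place of 4-fluorophenyl on a sulfonyl sulfur, gives a 1.4-fold lower number from compound 2 to compound 3 (0.15 log units; within the scatter) and leaves compound 3 level with compound 2. So swapping these two aromatic groups, even with a nitrile and its hydrogen-bond acceptor entering, does not separate the compounds on this read-out. No measurement shown here offers an explanation for this result. Still open, going by these compounds, is whether an amine or a carboxylic acid on this ring, or a longer alkyl chain in its place, would give a number clearly apart from these.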